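This account rests on a few compounds, and the source may have more. Where it says the series, first, only, none or still open, it means among the compounds named here.

Compound 1 `O=C1O[C@H]([C@@H](O)Cn2cc(-c3ccc(Br)cc3)nn2)C(OCc2ccccc2)=C1OCc1ccccc1` gives 5620 nM in a functional assay on MCF7 cells (Homo sapiens) for antiproliferative activity, read by MTT assay, with a stated time of 72 h; on this read-out higher numbers stand for weaker inhibition and lower numbers for stronger inhibition.
Compound 2 `COc1ccccc1-c1cn(C[C@H](O)[C@H]2OC(=O)C(OCc3ccccc3)=C2OCc2ccccc2)nn1` reaches only a limit of this assay, > 100000 nM, so no number is known for compound 2.
Compound 3 `CC(C)(C)c1cn(C[C@H](O)[C@H]2OC(=O)C(OCc3ccccc3)=C2OCc2ccccc2)nn1` gives 730 nM in this assay.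

Among these three, compound 3 carries the lowest number, and its nearest measured neighbour is compound 1, from which the step of a 7.7-fold lower number from compound 1 to compound 3 (0.89 log units; beyond the scatter) runs. The step from the aryl-bearing compound 2 to compound 3, an at least 130-fold lower number from compound 2 to compound 3 (2.13 log units; beyond the scatter), is larger still, though it starts from a limit (the limit of > 100000 nM in this assay, at which 1 of the 3 values shown sits).

Compound 4 `O=C1O[C@H]([C@@H](O)Cn2cc(-c3cc(F)cc(F)c3)nn2)C(OCc2ccccc2)=C1OCc1ccccc1` has not yet been measured. It differs from compound 3 by 3,5-difluorophenyl in place of tert-butyl on an aromatic carbon. Among the measured compounds shown here, the steps that bear on this change are the two in which the tert-butyl group stands against an aryl group: a 7.7-fold lower number from compound 1 to compound 3 (0.89 log units; beyond the scatter) and an at least 130-fold lower number from compound 2 to compound 3 (2.13 log units; beyond the scatter). Both run in the same direction, the tert-butyl compound giving the lower number, and both are beyond the scatter. Among the two measured aryl groups, 4-bromophenyl behaved far better than 2-methoxyphenyl, as an at least 17-fold higher number from compound 1 to compound 2 (1.25 log units; beyond the scatter) shows, and 3,5-difluorophenyl, a halogen-bearing ring, is the closer relative of 4-bromophenyl. Compound 4 is therefore expected to show a higher number than compound 3 in this assay, a step of about a 6.8-fold higher number from compound 3 to compound 4 (0.84 log units; beyond the scatter). The estimate for compound 4 in this assay is 5000 nM, with a range from 1500 nM to 30000 nM.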

Compound 4, half-maximal inhibitory concentration: 27700 nM
Beside the measured number, compound 4's estimate is 5.5-fold (0.74 log units) below it; the measured number falls inside the stated range.
By their numbers in this assay, from the lowest: compound 3; then compound 1; then compound 4. At a limit, above all of these: compound 2.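

With 3,5-difluorophenyl, all three aryl groups shown on this aromatic carbon give higher numbers than tert-butyl in this assay, and this newest comparison is a large one, with a 38-fold higher number from compound 3 to compound 4 (1.58 log units; beyond the scatter). Among the compounds shown here, the two halogen-bearing aryl groups are also not interchangeable here, since the swap of one for the other gives a 4.9-fold higher number from compound 1 to compound 4 (0.69 log units; beyond the scatter), a step beyond the scatter that the earlier compounds could not reveal. The 3,5-difluorophenyl group still sits on the lower side of 2-methoxyphenyl, with an at least 3.6-fold lower number from compound 2 to compound 4 (0.55 log units; beyond the scatter), but this step starts from a limit of the assay and so gives only a minimum size: the limit of > 100000 nM in this assay, at which 1 of the 4 values shown sits.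

The compounds shown leave open whether other alkyl groups on this carbon, such as isopropyl, cyclohexyl or a longer chain, would keep the number close to that of compound 3, as tert-butyl is the only group here without a ring. Also open is how an aryl ring carrying an amine or a carboxylic acid would rank against the aryl groups already shown.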